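Methoxy for Methyl on a Fused Ring Pair

The source may hold more compounds than are shown below. What is called first, only, known or untested is meant among the compounds shown, and "the series" means these compounds.

Measured so far:
Compound 1, `Cc1ccc(C2=Nn3c(nnc3-c3cc(Cl)cc(Cl)c3Cl)SC2)cc1`: 19.4%
Compound 2, `Cc1ccc(-c2nn3c(-c4cc(Cl)cc(Cl)c4Cl)nnc3s2)cc1`: 22.6%

Both compounds were tested in a functional assay on the whole organism with Rattus norvegicus as the target, read by paw edema, at a dose of 50 mg/kg by the oral route; a higher number here means more inhibition at the dose given (going by the name of the read-out), a lower number less inhibition. Compound 2, with 22.6%, gives the higher of the two numbers, but its gap to compound 1 lies within the usual scatter of this measurement, so the two cannot be told apart on these figures. Compound 2 shares its fused core with compound 3, `COc1ccc(-c2nn3c(-c4cc(Cl)cc(Cl)c4Cl)nnc3s2)cc1`, which differs in one place: methoxy in place of methyl on an aromatic carbon. Nothing measured here shows what such an exchange does in this assay, and the methoxy group is only slightly larger than the methyl it replaces. The expectation is therefore no step beyond the scatter, with compound 3 estimated at 22%, between 10% and 35%. This estimate means an expected step of a number 0.6 percentage points lower from compound 2 to compound 3 (within the scatter).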

Compound 3, a percentage reported as inhibition, in the whole organism at one dose (the size of the read-out at that dose, not a potency): 25.8%
Beside the measured number, compound 3's estimate is 3.8 percentage points below it, within the range that was stated.
By their numbers in this assay, from the lowest: compounds 1, 2 and 3 (each within the scatter of the next).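

In this assay, the exchange of 4-methylphenyl for 4-methoxyphenyl gives a number 3.2 percentage points higher from compound 2 to compound 3 (within the scatter), so on this shared core the two groups cannot be told apart at this dose. Within the data shown here, this is the only single change that can be read so far, and it shows that adding a hydrogen-bond acceptor at this spot, by the count of the two structures, brings no step beyond the scatter. No measurement available here bears on the reason for this result.

The compounds shown leave open whether a different group on this aromatic carbon, such as an amine, a carboxylic acid or a longer chain like butoxy, would move the number beyond the scatter. They also leave open whether methoxy in place of methyl would read the same way on the core of compound 1.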